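Lengthening the Amine Substituent in a Leukotriene Hydrolase Series

The source may report more compounds than this note shows. Statements on the series, on what has been measured and on what is new or still open speak of the compounds shown alone.

Compound 1 `O=C(CCc1ccc(OCc2ccccc2)cc1)NCC1CCN(Cc2cccs2)CC1` holds the lower of the two measured numbers in an assay on cells for inhibition of leukotriene A-4 hydrolase (Homo sapiens), read by fluorescence, with a stated time of 30 min (on this read-out lower numbers stand for stronger inhibition and higher numbers for weaker inhibition), where compound 1 gives 750 nM. Compound 2 `O=C(CCc1ccc(OCc2ccccc2)cc1)NCCC1CCN(Cc2ccccc2)C1`, which differs from it in several places, gives 3200 nM in this assay, and that gap lies beyond the scatter of the measurement, so compound 1 stands clearly lower. Compound 3 `O=C(CCc1ccc(OCc2ccccc2)cc1)NCC1CCN(CCCc2ccccc2)CC1` has not yet been measured. It differs from compound 1 in a single place: phenethyl in place of thiophen-2-yl on a saturated chain carbon bound to an amine nitrogen in a ring. Among the compounds with values here, no comparison between measured compounds isolates this change, and the two values of compound 1 and compound 2 show only that the second is higher. The writer therefore expects a modest step, a 1.6-fold higher number from compound 1 to compound 3 (0.20 log units; within the scatter), toward a somewhat higher number, one that may well fall within the scatter. Compound 3 is estimated to give 1200 nM in this assay, with a range from 300 nM to 5000 nM.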

Compound 3, half-maximal inhibitory concentration: 18300 nM
The estimate for compound 3 lay 15-fold (1.18 log units) below the measured number; measured number outside the range, above it.
By their numbers in this assay, from the lowest: compound 1; then compound 2; then compound 3.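

In this assay, the place on a saturated chain carbon bound to an amine nitrogen in a ring proves highly sensitive: phenethyl in place of thiophen-2-yl gives a 24-fold higher number from compound 1 to compound 3 (1.39 log units; beyond the scatter), a large step well beyond the scatter. Within the data shown here, this is the first comparison that isolates one change, and it shows that this substituent alone can move the number this far while the rest of compound 1 stays the same. Nothing measured here explains the step.

The change swaps the ring and lengthens the chain together, so the compounds shown cannot say which of the two matters. A furan-2-yl in place of thiophen-2-yl would alter the ring alone, while a 3-(thiophen-2-yl)propyl group would alter the chain alone.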